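Removing the Fluoro Group: Compound 3 to Compound 4

The source may hold more compounds than are shown below. What is called first, only, known or untested is meant among the compounds shown, and "the series" means these compounds.

Compound 1 `CC(C)CCc1ccc2c(NCCCNCc3ccco3)ccnc2c1` gives 11200 nM in an ADME assay on HepG2 cells (Homo sapiens) for cytotoxicity, read by luminescence, CellTiter-Glo and ATP content, with a stated time of 72 h; a higher number here means that more compound is needed for the effect, a lower number that less compound is needed.
Compound 2 `Fc1ccc(Oc2ccc3c(NCCCNCc4ccco4)ccnc3c2)cc1` gives 16000 nM in this assay.
Compound 3 `Fc1ccc(Cc2ccc3c(NCCCNCc4ccco4)ccnc3c2)cc1` gives 5600 nM in this assay.

All three share one core and differ only in the group hung from one aromatic carbon. Compound 3 has the lowest number of the three, though one of the two steps that lead to it is a 2.0-fold lower number from compound 1 to compound 3 (0.30 log units; within the scatter) and so lies within the scatter, while the other is a 2.9-fold lower number from compound 2 to compound 3 (0.46 log units; beyond the scatter), a modest step beyond it.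

Compound 4 `c1ccc(Cc2ccc3c(NCCCNCc4ccco4)ccnc3c2)cc1` is compound 3 with one small change: hydrogen in place of fluoro on an aromatic carbon. The 4-fluorobenzyl group becomes a benzyl group.

Going by the values given here, none of the measured steps removes a fluoro group on its own. The steps of a 2.0-fold lower number from compound 1 to compound 3 (0.30 log units; within the scatter) and a 2.9-fold lower number from compound 2 to compound 3 (0.46 log units; beyond the scatter) exchange whole groups, and compound 2 keeps its fluoro while differing elsewhere, so they say little about this one atom. Among the compounds with values here, with no step that bears directly on it, the expectation is no change beyond the scatter, with the step of a 1.2-fold higher number from compound 3 to compound 4 (0.06 log units; within the scatter) expected to stay small. Compound 4 is therefore estimated at 6500 nM, within a range of 3000 nM to 14000 nM.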

Compound 4, half-maximal effective concentration: 16000 nM
Estimate against measurement, compound 4: 2.5-fold (0.39 log units) below; measured number outside the range, above it.
By their numbers in this assay, from the lowest: compounds 3, 1, 2 and 4 (each within the scatter of the next, the first and the last beyond it).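

In this assay, one atom at this place is enough for a step beyond the scatter: the change to hydrogen, on a carbon para to a large group, gives a 2.9-fold higher number from compound 3 to compound 4 (0.46 log units; beyond the scatter), so more compound is needed for the effect without the fluoro. The earlier steps exchanged whole groups and could not isolate this atom; here the 4-fluorobenzyl and benzyl groups, which differ by that atom alone, are shown not to be interchangeable. The benzyl group also stands level with the other two groups, with no change at the digits printed from compound 2 to compound 4 (within the scatter) and a 1.4-fold higher number from compound 1 to compound 4 (0.15 log units; within the scatter), and no measurement on hand explains why this single atom matters.

The compounds shown leave open whether the effect is specific to fluoro or would also appear with a chloro or methoxy group at the same place on the benzyl ring, since a single modest step rests on just one pair of compounds. They also leave open whether exchanging fluoro for hydrogen on the 4-fluorophenoxy group of compound 2 would produce any step at all.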